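The source may report more compounds than this note shows. Statements on the series, on what has been measured and on what is new or still open speak of the compounds shown alone.

Measured so far in a physicochemical assay for solubility, read by HPLC, using the shake flask method (on this read-out higher numbers stand for higher solubility and lower numbers for lower solubility), and shown here:
compound 1 `COC(=O)c1cccc(-c2cnc3[nH]cc(-c4ccccc4)c3c2)c1` gives 2500 nM
compound 2 `COC(=O)c1cccc(-c2cnc3[nH]cc(-c4cncnc4)c3c2)c1` gives 4600 nM
compound 3 `COC(=O)c1cccc(-c2cnc3[nH]cc(-c4cccc(OC)c4)c3c2)c1` gives 1000 nM

Compound 1 cannot be separated from one neighbour and lies clear of the other: the numbers show a 1.8-fold higher number from compound 1 to compound 2 (0.26 log units; within the scatter) and also a 2.5-fold lower number from compound 1 to compound 3 (0.40 log units; beyond the scatter) on the other side. Compound 4 `COC(=O)c1cccc(-c2cnc3[nH]cc(-c4ccncc4)c3c2)c1` is still to be measured in this assay and differs from compound 1 in one group. Pyridin-4-yl stands in place of phenyl on an aromatic carbon (pyridin-4-yl in place of phenyl on an aromatic carbon) of a five-membered aromatic ring with 1 nitrogen, two ring bonds from the ring nitrogen. The nearest guide is the swap to pyrimidin-5-yl on that same carbon, which gave a 1.8-fold higher number from compound 1 to compound 2 (0.26 log units; within the scatter) and nothing more. The methoxy change with a 2.5-fold lower number from compound 1 to compound 3 (0.40 log units; beyond the scatter) and the swap with a 4.6-fold lower number from compound 2 to compound 3 (0.66 log units; beyond the scatter) both bring in a methoxy group that compound 4 lacks, so they say little here. A small upward move, no larger than the scatter, is therefore expected. The expected step on this estimate is a 1.6-fold higher number from compound 1 to compound 4 (0.20 log units; within the scatter) and no more. For compound 4 the estimated value is 4000 nM with an expected range from 1800 nM to 9000 nM as the likely span of repeat measurements.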

Compound 4, solubility: 30900 nM
Compound 4: the middle estimate sits 7.7-fold (0.89 log units) below what was measured, and the stated range ends below it.
By their numbers in this assay, from the lowest: compound 3; then compounds 1 and 2 (each within the scatter of the next); then compound 4.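

In this assay, this aromatic carbon of the five-membered ring proves able to carry a large step from a small edit: pyridin-4-yl has the same heavy-atom count as phenyl, with one ring carbon exchanged for nitrogen, yet the swap brings a 12-fold higher number from compound 1 to compound 4 (1.09 log units; beyond the scatter). The earlier swap to pyrimidin-5-yl gave no sign of this, and the new group stands clearly apart from that ring too, with a 6.7-fold higher number from compound 2 to compound 4 (0.83 log units; beyond the scatter), so among these compounds the mere presence of ring nitrogen does not set the size of the step. The range spanned at this one carbon now reaches a 31-fold higher number from compound 3 to compound 4 (1.49 log units; beyond the scatter), much wider than the earlier compounds showed, and nothing measured here accounts for the rise.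

The compounds shown leave open whether the place of the nitrogen in the ring matters, as a pyridin-3-yl group would test, and whether an amine on the pyridine ring would move the number further. Also open, as far as these compounds go, is whether the step holds with a carboxylic acid in place of the methyl ester.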